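The compounds below may be only part of what the source reports. "The series", "measured", "known", "first", "only" and "open" are said of these compounds alone.

Measured so far in an assay on CHO-K1 cells for displacement of a labelled ligand from prostaglandin E2 receptor EP1 subtype (Homo sapiens); on this read-out higher numbers stand for weaker inhibition and lower numbers for stronger inhibition:
compound 1, `Cc1cc(C(=O)O)nn1Cc1cc(Br)ccc1OCc1ccccc1`: 6.46 nM
compound 2, `Cc1cc(C(=O)O)nn1Cc1cc(Br)ccc1OCc1cccc(Br)c1`: 17.8 nM

Among the compounds with values here, compound 2 stands at the highest of these two numbers in this assay; the one step measured, a 2.8-fold higher number from compound 1 to compound 2 (0.44 log units; beyond the scatter), came from bromo in place of hydrogen on an aromatic carbon. Compound 3, `Cc1cc(C(=O)O)nn1Cc1cc(Br)ccc1OCc1cccc(Cl)c1`, differs from compound 2 by chloro in place of bromo on an aromatic carbon, meta to a large group. Within the data shown here, no measured step covers a swap of one halogen for another, and the step ending at compound 2 only shows that this position tolerates a halogen with a modest loss. Compound 3 is therefore expected to give about 14 nM in this assay, within 6 nM to 35 nM, a step of a 1.3-fold lower number from compound 2 to compound 3 (0.10 log units; within the scatter) that is expected to stay within the scatter.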

Compound 3, half-maximal inhibitory concentration: 115 nM
The estimate for compound 3 lay 8.2-fold (0.91 log units) below the measured number, and the stated range ends below it.
By their numbers in this assay, from the lowest: compound 1; then compound 2; then compound 3.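

In this assay, the swap from 3-bromophenyl to 3-chlorophenyl gave a clear loss (a 6.5-fold higher number from compound 2 to compound 3 (0.81 log units; beyond the scatter)), so the two halogens are not interchangeable at this place on the ring. Measured against hydrogen, chloro gave a larger change (an 18-fold higher number from compound 1 to compound 3 (1.25 log units; beyond the scatter)) than bromo did (a 2.8-fold higher number from compound 1 to compound 2 (0.44 log units; beyond the scatter)). Nothing available accounts for this gap between the two halogens. The compounds shown leave open whether fluoro, methyl or methoxy at this place would sit nearer hydrogen, bromo or chloro.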